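Difluoromethoxy for Fluoro on the Amide Ring

A few compounds are considered here, and "the series" means these few. Any claim that something is new, unique, unknown or untested is made for them only; others in the source may bear on it.

Compound 1 `CCN(CC)c1cc2[nH]c(C3CCCCC3)nc2cc1NC(=O)OCC(F)(F)F` and compound 2 `CCN(CC)c1cc2[nH]c(C3CCCCC3)nc2cc1NC(=O)c1ccc(F)cc1` share one core and differ only in the group on the carbonyl carbon. In an ADME assay on Vero cells (Chlorocebus sabaeus) for cytotoxicity, read by resazurin assay, with a stated time of 3 days (on this read-out higher numbers stand for weaker inhibition and lower numbers for stronger inhibition), compound 1 gives a value that is a limit of the assay, > 100 ug/mL. In this assay compound 2 also gives only a limit, > 100 ug/mL. Compound 2 therefore stands at the limit, together with compound 1, and the step that the two limits leave unreadable from compound 1 to compound 2 cannot be read because the limit of > 100 ug/mL in this assay, at which 2 of the 2 values shown sit, holds both values.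

Compound 3 `CCN(CC)c1cc2[nH]c(C3CCCCC3)nc2cc1NC(=O)c1ccc(OC(F)F)cc1` has not been measured in this assay. Its difference from compound 2 is difluoromethoxy in place of fluoro on an aromatic carbon. Going by the values given here, no measured step involves this change; the only step available, from a trifluoroethoxy to a 4-fluorophenyl group on the carbonyl carbon, gave no readable size. Nothing in the measured values points to a step in either direction, so the step of a number no higher from compound 2 to compound 3 (the limit leaves the size open) is expected to be none beyond the scatter. Compound 3 is expected to give 100 ug/mL in this assay, with a range from 50 ug/mL to 200 ug/mL, most likely again reported as a limit.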

Compound 3, half-maximal inhibitory concentration: > 100 ug/mL
Compound 3: a limit, no number; the forecaster's own chance of this, stated with the estimate: 80%; the middle value sits exactly at the limit.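

In this assay compound 3 gives > 100 ug/mL, which is again a limit of the assay. The steps from compound 1 and from compound 2 to compound 3 therefore cannot be read, since all three values are held at one limit: the limit of > 100 ug/mL in this assay, at which 3 of the 3 values shown sit.

The compounds shown leave open how far the true value of each lies from that limit, and whether difluoromethoxy in place of fluoro changes the result in this assay at all.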